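Trifluoromethoxyphenyl variant of compound 3: cytotoxicity outlook

The source may report more compounds than this note shows. Statements on the series, on what has been measured and on what is new or still open speak of the compounds shown alone.

Compound 1 `Cc1ccccc1-c1nn(-c2cc(F)ccc2F)cc1CNCCN1CCN(C)CC1` carries a 2,5-difluorophenyl group on an aromatic nitrogen. In an ADME assay on Huh-7 cells (Homo sapiens) for cytotoxicity (a lower number here means that less compound is tolerated, a higher number that more compound is tolerated), compound 1 gives > 20000 nM, which is a limit of the assay and not a number. Compound 2 `CCOC(=O)Cn1cc(CNCCN2CCN(C)CC2)c(-c2ccccc2C)n1` has (ethoxycarbonyl)methyl in that place. In this assay compound 2 gives > 20000 nM, again a limit. The step that the two limits leave unreadable from compound 1 to compound 2 is therefore not readable. Among the compounds with values here, compound 3 `Cc1ccccc1-c1nn(-c2cccc(C(F)(F)F)c2)cc1CNCCN1CCN(C)CC1` bears 3-(trifluoromethyl)phenyl and in this assay gives 18000 nM, the only actual number among the three; the other two values sit at the limit of > 20000 nM in this assay, at which 2 of the 3 values shown sit. The steps of an at least 1.1-fold lower number from compound 1 to compound 3 (0.04 log units; that floor lies within the scatter) and an at least 1.1-fold lower number from compound 2 to compound 3 (0.04 log units; that floor lies within the scatter) set floors only, both within the scatter.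

Compound 4 `Cc1ccccc1-c1nn(-c2ccc(OC(F)(F)F)cc2)cc1CNCCN1CCN(C)CC1` differs from compound 3 in one place: 4-(trifluoromethoxy)phenyl in place of 3-(trifluoromethyl)phenyl on an aromatic nitrogen. Within the data shown here, the one measured aryl-for-aryl change on that nitrogen, an at least 1.1-fold lower number from compound 1 to compound 3 (0.04 log units; that floor lies within the scatter), bears on this change, and its floor lies within the scatter. On that basis the expected step of a 1.1-fold higher number from compound 3 to compound 4 (0.05 log units; within the scatter) in this assay stays within the scatter. The estimate for compound 4 in this assay is 20000 nM, with a range from 9000 nM to 45000 nM, and a fair chance that only a limit is reported.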

Compound 4, half-maximal cytotoxic concentration: 17000 nM
Compound 4: the middle estimate sits 1.2-fold (0.07 log units) above what was measured, and the stated range covers the measured number.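

Within the data shown here, compound 4 gives the first step on this aromatic nitrogen with a measured number at both ends: a 1.1-fold lower number from compound 3 to compound 4 (0.02 log units; within the scatter). Exchanging 3-(trifluoromethyl)phenyl for 4-(trifluoromethoxy)phenyl, with its oxygen and one hydrogen-bond acceptor, therefore stays within the scatter in this assay. The steps of an at least 1.1-fold lower number from compound 2 to compound 4 (0.07 log units; that floor lies within the scatter) and an at least 1.1-fold lower number from compound 1 to compound 4 (0.07 log units; that floor lies within the scatter) set floors only, and those floors also stay within the scatter, as they start from a limit: the limit of > 20000 nM in this assay, at which 2 of the 4 values shown sit.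

The compounds shown leave open whether any group on this nitrogen moves the number beyond the scatter in this assay, for example a phenyl ring bearing an amine or a carboxylic acid. Also open, on these data alone, is the size of any step from compound 1 or compound 2, whose limits give no number to compare.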